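Swapping Chloro for 2-Hydroxyethyl on an Aromatic Ring

A few compounds are considered here, and "the series" means these few. Any claim that something is new, unique, unknown or untested is made for them only; others in the source may bear on it.

Compound 1: `CC1CC/C(=N\Nc2ccccc2Cl)c2ncc(C(=O)O)c(=O)n21` — > 1000 umol/kg
Compound 2: `COc1ccc(N/N=C2\CCC(C)n3c2ncc(C(=O)O)c3=O)cc1` — 7.6 umol/kg

Both compounds were tested in a functional assay on the whole organism for inhibition, with Rattus norvegicus as the target; a lower number here means that less compound is needed, a higher number that more compound is needed for the effect. For compound 1 the result is only a limit of the assay, not a number (the limit of > 1000 umol/kg in this assay, at which 1 of the 2 values shown sits). Compound 2, in contrast, gives 7.6 umol/kg in this assay. Going by the values given here, the one measured step is an at least 130-fold lower number from compound 1 to compound 2 (2.11 log units; beyond the scatter), so compound 1 stands at the weak end of what is known.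

Compound 3, `CC1CC/C(=N\Nc2ccccc2CCO)c2ncc(C(=O)O)c(=O)n21`, differs from compound 1 by 2-hydroxyethyl in place of chloro on an aromatic carbon. Among the compounds with values here, no measured step shows this change: the step from compound 1 to compound 2 exchanged the whole aryl group and placed its substituent elsewhere, so it bears on compound 3 only by showing that the aryl substitution matters. Since compound 1 sits at the limit, the step from compound 1 to compound 3 is expected to be an at least 3.3-fold lower number from compound 1 to compound 3 (0.52 log units; beyond the scatter), with wide uncertainty. Compound 3 is estimated at 300 umol/kg, between 30 umol/kg and 1500 umol/kg.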

Compound 3, dose for 50% inhibition: > 100 umol/kg
Compound 3: no number, only a limit; the forecaster's own chance of this, stated with the estimate: 45%; the middle value is on the limit's open side.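

Compound 1 and compound 3 each carry only a limit of the assay, not a number, so the step between them cannot be read. From the compounds shown here alone, it remains open whether 2-hydroxyethyl in place of chloro changes the dose needed, and by how much.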